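The source may hold more compounds than are shown below. What is called first, only, known or untested is meant among the compounds shown, and "the series" means these compounds.

Of the compounds shown here, two have been measured. Compound 1 `Cc1cnc(-c2ccc(Cl)c(C(=O)NCC3(O)CCCCCC3)c2)cn1` gives, in a functional assay on HEK293 cells for antagonist activity at P2X purinoceptor 7 (Homo sapiens) (a lower number here means a stronger inhibitor, a higher number a weaker inhibitor), a value of 22 nM. Compound 2 `O=C(NCC1(O)CCCCCC1)c1cc(-c2ccc(CO)cn2)ccc1Cl` is its close relative, and in this assay compound 2 gives 17 nM. Within the data shown here, the step from one to the other, a 1.3-fold lower number from compound 1 to compound 2 (0.11 log units; within the scatter), exchanges the whole heteroaryl group and yet lands within the scatter, so compound 2 stands beside compound 1 rather than apart from it; with only two numbers in hand, its position is simply that of one of two comparable values.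

Compound 3 `N#Cc1ccc(-c2ccc(Cl)c(C(=O)NCC3(O)CCCCCC3)c2)nc1` has not yet been measured. It differs from compound 2 in one place: cyano in place of hydroxymethyl on an aromatic carbon. Among the measured compounds shown here, no measured step touches this exact exchange; the only step available, from compound 1 to compound 2, concerns a different part of the molecule and was itself within the scatter. On that basis the expected step of a 1.2-fold higher number from compound 2 to compound 3 (0.07 log units; within the scatter) is small in either direction, with no change beyond the scatter foreseen. For compound 3 the estimate in this assay is 20 nM, with a range from 7 nM to 60 nM.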

Compound 3, half-maximal inhibitory concentration: 134 nM
The estimate for compound 3 lay 6.7-fold (0.83 log units) below the measured number; the measured number lies above the stated range.
By their numbers in this assay, from the lowest: compounds 2 and 1 (each within the scatter of the next); then compound 3.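

In this assay, the aromatic carbon two atoms from the ring nitrogen and para to a large group proves sensitive to what it carries: a 7.9-fold higher number from compound 2 to compound 3 (0.90 log units; beyond the scatter) is a step beyond the scatter, although cyano and hydroxymethyl each count 2 heavy atoms and no net charge. The earlier exchange of one whole heteroaryl group for another had stayed within the scatter, yet a 6.1-fold higher number from compound 1 to compound 3 (0.78 log units; beyond the scatter) also goes beyond it, so 5-cyanopyridin-2-yl parts from the two heteroaryl groups that gave comparable numbers. The change takes the count of hydrogen-bond donors on this group from 1 to 0 while the acceptor count stays at 1, but nothing measured here gives a reason for the step.

The compounds shown leave open how an aminomethyl group, a methoxymethyl group, a carboxylic acid or the longer hydroxyethyl chain would fare on this same carbon. They also leave open whether cyano would give a similar step on the ring that carries the methyl group in compound 1.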